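Swapping the propyl for a 2-methoxyethoxy chain

The compounds below may be only part of what the source reports. "The series", "measured", "known", "first", "only" and "open" are said of these compounds alone.

Compound 2, with the structure `CCCc1ncc(-c2nc(C(F)(F)F)sc2N2CCN(C(=O)Cn3cnc4cccnc43)[C@H](C)C2)cn1`, gives 33 nM in a functional assay on U2OS cells for antagonist activity at C-X-C chemokine receptor type 3 (Homo sapiens), read by beta-arrestin recruitment; on this read-out lower numbers stand for stronger inhibition and higher numbers for weaker inhibition. Among the compounds with values here, of the two numbers measured so far it is the higher one, but its nearest neighbour is compound 1, `C[C@@H]1CN(c2sc(C(F)(F)F)nc2-c2nc3ccccc3[nH]2)CCN1C(=O)Cn1cnc2cccnc21`, which gives 31 nM; the two values lie within the scatter of each other, so no order between them can be claimed. Within the data shown here, the one measured step, a 1.1-fold higher number from compound 1 to compound 2 (0.03 log units; within the scatter), exchanged the group on the shared core and left the read-out essentially unchanged. Compound 3, `COCCOc1ncc(-c2nc(C(F)(F)F)sc2N2CCN(C(=O)Cn3cnc4cccnc43)[C@H](C)C2)cn1`, differs from compound 2 at a different place: 2-methoxyethoxy in place of propyl on an aromatic carbon. Among the measured compounds shown here, no measured step touches this position, so the measured step gives only a general hint that this series tolerates changes without large shifts. Compound 3 is therefore expected to show no step beyond the scatter, a 1.2-fold higher number from compound 2 to compound 3 (0.08 log units; within the scatter), with an estimate of 40 nM, ranging from 15 nM to 120 nM.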

Compound 3, half-maximal inhibitory concentration: 324 nM
Compound 3: the middle estimate sits 8.1-fold (0.91 log units) below what was measured; the measured number lies above the stated range.
By their numbers in this assay, from the lowest: compounds 1 and 2 (each within the scatter of the next); then compound 3.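

In this assay this position proves sensitive: on the aromatic carbon between two ring nitrogen atoms, 2-methoxyethoxy in place of propyl gives a 9.8-fold higher number from compound 2 to compound 3 (0.99 log units; beyond the scatter), a step beyond the scatter. The earlier exchange of a whole group on the shared core stayed within the scatter, but that tolerance does not carry over to this chain, since the 2-(2-methoxyethoxy)pyrimidin-5-yl group also gives a 10-fold higher number from compound 1 to compound 3 (1.02 log units; beyond the scatter). Nothing available here bears on why the number rises at this position.

The compounds shown leave open whether the rise follows the oxygen attached to the ring or the oxygen further along the chain. A butyl chain, a methoxy group or an amine at this position could help separate these possibilities.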